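Chloro to Methoxy, Repeated on a Second Core

The source may hold more compounds than are shown below. What is called first, only, known or untested is meant among the compounds shown, and "the series" means these compounds.

Compound 1 `Clc1ccc2oc(C(c3ccccc3)c3c[nH]c4ccccc34)cc2c1` gives 58000 nM in a functional assay on SiHa cells (Homo sapiens) for cytotoxicity; a lower number here means a stronger inhibitor, a higher number a weaker inhibitor.
Compound 2 `COc1ccc2oc(C(c3ccccc3)c3c[nH]c4ccccc34)cc2c1` gives > 100000 nM in this assay, which is a limit of the assay and not a number.
Compound 3 `CC(C)(C)c1cc(C(C)(C)C)c2oc(C(c3ccc(Cl)cc3)c3c[nH]c4ccc([N+](=O)[O-])cc34)cc2c1` gives 36900 nM in this assay.

Compounds 1 and 2 share one core and differ in a single place: methoxy in place of chloro on an aromatic carbon. That change gave an at least 1.7-fold higher number from compound 1 to compound 2 (0.23 log units; that floor lies within the scatter). The size of this step is only a floor, because compound 2 sits at the limit of > 100000 nM in this assay, at which 1 of the 3 values shown sits. Compound 3 carries a different core; the difference between the two cores is not broken down here. Of the two numbers, compound 3 has the lowest, with compound 1 nearest and within the scatter, so no order between them is claimed.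

Compound 4 `COc1ccc(C(c2cc3cc(C(C)(C)C)cc(C(C)(C)C)c3o2)c2c[nH]c3ccc([N+](=O)[O-])cc23)cc1` is not yet measured. It differs from compound 3 by the same kind of change: methoxy in place of chloro on an aromatic carbon. The surroundings are not the same: in compound 1 the group sits on a ring that is part of a fused or bridged system of two rings, meta to a fused ring and para to a fused ring, while in compound 3 it sits on a six-membered aromatic ring of carbon only, para to a large group.

The expected step from compound 3 to compound 4 in this assay is a 1.9-fold higher number from compound 3 to compound 4 (0.28 log units; within the scatter), resting on an at least 1.7-fold higher number from compound 1 to compound 2 (0.23 log units; that floor lies within the scatter). Compound 4 is therefore estimated at 70000 nM, with a likely range from 30000 nM to 150000 nM. A limit rather than a number is a real possibility for compound 4.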

Compound 4, half-maximal inhibitory concentration: > 100000 nM
Compound 4: only a limit was reported (the forecaster's own chance of this, stated with the estimate: 35%); middle value at least 1.4-fold (0.15 log units) from the limit.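

Compound 4 gives > 100000 nM in this assay, which is a limit of the assay and not a number. Putting methoxy in place of chloro, which here turns a 4-chlorophenyl group into a 4-methoxyphenyl group, gave an at least 2.7-fold higher number from compound 3 to compound 4 (0.43 log units; beyond the scatter), so on this core the step clears the usual scatter even though its true size is known only as a floor. Both cores thus point the same way, towards a higher number and a weaker inhibitor with methoxy, although the floor on the first core does not clear the scatter, and the data cannot show whether the change has the same size on the two cores: the same change on two cores in this assay, an at least 1.7-fold higher number (0.23 log units; that floor lies within the scatter) from compound 1 to compound 2 and an at least 2.7-fold higher number (0.43 log units; beyond the scatter) from compound 3 to compound 4; the limit leaves it open whether they differ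

From the compounds shown here alone, what remains open is how large either step really is, and how much weaker either methoxy compound is than its chloro partner. Going by these compounds, it is also open whether the higher number belongs to methoxy in particular, which a comparison with other groups on the same aromatic carbon, such as a hydroxyl, an amine or a fluorine atom, could begin to answer.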